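A Hydroxy for a Methoxy on a Shared Core

A few compounds are considered here, and "the series" means these few. Any claim that something is new, unique, unknown or untested is made for them only; others in the source may bear on it.

Of the compounds shown here, three have been measured in a functional assay on HOP-92 cells (Homo sapiens) for inhibition, read by sulforhodamine B assay, with a stated time of 48 h; a lower number here means a stronger inhibitor of growth, a higher number a weaker inhibitor of growth. Compound 1 `COc1cc(-c2nn(-c3cccc(NC(=O)Nc4cc(C(F)(F)F)cc(C(F)(F)F)c4)c3)cc2-c2ccncc2)ccc1Cl` gives 1150 nM. Compound 2 `COc1cc(-c2nn(-c3cccc(NC(=O)Nc4ccc(Cl)c(Cl)c4)c3)cc2-c2ccncc2)ccc1Cl` gives 1470 nM. How the core of compound 1 differs from the core of compound 2 is not broken down here. Compound 3 `O=C(Nc1cccc(-n2cc(-c3ccncc3)c(-c3ccc(Cl)c(O)c3)n2)c1)Nc1ccc(Cl)c(Cl)c1` gives 1910 nM. Compound 3 differs from compound 2 by one change, (hydrogen in place of methyl on an oxygen on an aromatic ring), and that change made a 1.3-fold higher number from compound 2 to compound 3 (0.11 log units; within the scatter). The three values all lie within the scatter of one another, so no order among them can be read.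

Compound 4 `O=C(Nc1cccc(-n2cc(-c3ccncc3)c(-c3ccc(Cl)c(O)c3)n2)c1)Nc1cc(C(F)(F)F)cc(C(F)(F)F)c1` is not yet measured. It differs from compound 1 by hydrogen in place of methyl on an oxygen on an aromatic ring. Going by the values given here, the place of the change reads the same, word for word, in both pairs, so this is the same change as the one from compound 2 to compound 3. That earlier example stayed within the scatter. For compound 4 the expected step is a 1.3-fold higher number from compound 1 to compound 4 (0.12 log units; within the scatter), which rests on that earlier example. In this assay compound 4 is therefore estimated at 1500 nM, most likely between 800 nM and 2800 nM.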

Compound 4, concentration for total growth inhibition: 1750 nM
Beside the measured number, compound 4's estimate is 1.2-fold (0.07 log units) below it; the measured number falls inside the stated range.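

Replacing methoxy with hydroxy on the core of compound 1 gives, in this assay, a 1.5-fold higher number from compound 1 to compound 4 (0.18 log units; within the scatter). Set beside the earlier example, the change looks much the same on the two cores: the same change on two cores in this assay, a 1.3-fold higher number (0.11 log units; within the scatter) from compound 2 to compound 3 and a 1.5-fold higher number (0.18 log units; within the scatter) from compound 1 to compound 4, 1.2-fold (0.07 log units) apart, within the scatter of two such steps. This shows that, for these two pairs, the change can be carried from one core to the other without producing a step that stands out from the scatter, but it does not show that hydroxy truly differs from methoxy in this read-out, and two pairs cannot establish a rule for the whole series.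

The compounds shown leave open whether any other group on this oxygen-bearing position would produce a step beyond the scatter, such as an ethoxy group or a longer chain on the oxygen, or an amine in place of the hydroxy. They also leave open whether the same small step would hold on a core other than these two.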